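This account rests on a few compounds, and the source may have more. Where it says the series, first, only, none or still open, it means among the compounds named here.

In a functional assay on the whole organism for inhibition, with Mus musculus as the target, at a dose of 10 mg/kg (on this read-out higher numbers stand for more inhibition at the one dose given (going by the name of the read-out) and lower numbers for less inhibition), compound 1 `O=C1C=CS(=O)(=O)c2ccccc21` gives 5.5%, compound 2 `CCOCC1=CS(=O)(=O)c2ccccc2C1=O` gives 92.4% and compound 3 `O=C1C(COCCBr)=CS(=O)(=O)c2ccccc21` gives 100%. Compound 3 has the highest of the three numbers; its distance from compound 2 is within the scatter, so the two cannot be ordered, while its distance from compound 1 is beyond the scatter. The steps of a number 86.9 percentage points higher from compound 1 to compound 2 (beyond the scatter) and a number 94.5 percentage points higher from compound 1 to compound 3 (beyond the scatter) show that having a group on the double-bonded ring carbon accounts for almost the whole effect, whereas the step of a number 7.6 percentage points higher from compound 2 to compound 3 (within the scatter) shows that changing the far end of that chain made no difference beyond the scatter. Compound 4 `CCC(=O)OCC1=CS(=O)(=O)c2ccccc2C1=O` differs from compound 3 as follows: propanoyl in place of 2-bromoethyl on an oxygen on a saturated carbon. This keeps a chain on the double-bonded ring carbon and alters only its outer part, the sort of alteration that in this assay left compound 2 and compound 3 within the scatter of each other. Compound 4 is therefore expected to remain near the top, with an estimated step of a number 12 percentage points lower from compound 3 to compound 4 (beyond the scatter) that lies within the scatter. The estimate for compound 4 in this assay is 88%, expected to fall between 55% and 100%.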

Compound 4, a percentage reported as inhibition, in the whole organism at one dose (the size of the read-out at that dose, not a potency): 99.5%
Compound 4: middle estimate off by 11.5 percentage points, on the low side; the measured number falls inside the stated range.
By their numbers in this assay, from the lowest: compound 1; then compounds 2, 4 and 3 (each within the scatter of the next).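

In this assay the step of a number 0.5 percentage points lower from compound 3 to compound 4 (within the scatter) and the step of a number 7.1 percentage points higher from compound 2 to compound 4 (within the scatter) show that propanoyl on the oxygen on a saturated carbon cannot be told apart from 2-bromoethyl or ethyl there. The outer part of the chain can therefore carry a carbonyl, with its added hydrogen-bond acceptor, and the number stays within the scatter of the two earlier chains. The step of a number 94 percentage points higher from compound 1 to compound 4 (beyond the scatter) makes (propanoyloxy)methyl the third group on the double-bonded ring carbon to stand far above the bare core of compound 1.

The compounds shown leave open whether a plain methyl, or a chain ending in an amine or a carboxylic acid, would hold up at this position, and how the three chains would rank at another dose. No supporting evidence is available to explain these results.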